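The compounds below may be only part of what the source reports. "The series", "measured", "known", "first", "only" and "open" are said of these compounds alone.

Working notes on the nitrocatechol chalcone series. Compound 1 `O=C(/C=C/c1nccs1)c1cc(O)c(O)c([N+](=O)[O-])c1` and compound 2 `O=C(/C=C/c1cccc(O)c1)c1cc(O)c(O)c([N+](=O)[O-])c1` share the same core and differ only in the ring on the far end of the enone chain. In an assay for inhibition of Catechol O-methyltransferase (Rattus norvegicus), read by fluorescence and spectrophotometry (a higher number here means a weaker inhibitor, a lower number a stronger inhibitor), compound 1 gives 240 nM. In this assay compound 2 gives 140 nM. The step of a 1.7-fold lower number from compound 1 to compound 2 (0.23 log units; within the scatter) is within the scatter, so the two numbers cannot be separated and compound 2 stands level with compound 1 rather than apart from it.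

Compound 3 `N#Cc1cccc(/C=C/C(=O)c2cc(O)c(O)c([N+](=O)[O-])c2)c1` is the next member, not yet measured. Its change from compound 2 is cyano in place of hydroxy on an aromatic carbon. Among the measured compounds shown here, no measured step exchanges one substituent of this phenyl ring for another; the only step that bears on the region is the exchange of the whole ring from compound 1 to compound 2, and that moved the number by less than the scatter. On this basis no shift beyond the scatter is expected for compound 3, and the step of a 1.2-fold higher number from compound 2 to compound 3 (0.08 log units; within the scatter) is estimated as essentially flat. Compound 3 is therefore expected at 170 nM, within a range of 70 nM to 420 nM.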

Compound 3, half-maximal inhibitory concentration: 240 nM
The estimate for compound 3 lay 1.4-fold (0.15 log units) below the measured number, and the stated range covers the measured number.
By their numbers in this assay, from the lowest: compounds 2, 1 and 3 (each within the scatter of the next).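

In this assay, among the compounds shown here, the exchange of cyano for hydroxy on an aromatic carbon meta to a large group is the first change within the phenyl ring itself rather than of the whole ring, and it reads as a 1.7-fold higher number from compound 2 to compound 3 (0.23 log units; within the scatter) and so stays within the scatter. At this place, then, the hydrogen-bond donor counted on hydroxy can be removed and a two-atom cyano with a triple bond can enter without separating compound 3 from compound 2, so this single substituent exchange gives no sign that the position is sensitive in this assay. Nothing at hand bears on what lies behind this reading, and a flat step alone cannot settle it.

As far as these compounds go, whether a substituent of another kind at this same place, such as an amine, a carboxylic acid or a methoxy group, would move the number beyond the scatter remains open. Also open is whether hydroxy or cyano would read the same on another carbon of the ring, since all the phenyl compounds shown carry their substituent at this one place.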